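Compound 4: swapping the benzyl group of compound 3

A few compounds are considered here, and "the series" means these few. Any claim that something is new, unique, unknown or untested is made for them only; others in the source may bear on it.

In a functional assay on GBM2 cells (Homo sapiens) for antiproliferative activity, read by WST assay, with a stated time of 72 h (on this read-out lower numbers stand for stronger inhibition and higher numbers for weaker inhibition), compound 1 (`O=C(Nc1cccc(Cl)c1)Nc1cc2ncncc2cc1OCc1cccc(Cl)c1`) gives 3500 nM and compound 2 (`O=C(Nc1ccc(C(F)(F)F)cc1)Nc1cc2ncncc2cc1OCc1cccc(Cl)c1`) gives 4700 nM while compound 3 (`O=C(Nc1ccccc1F)Nc1cc2ncncc2cc1OCc1ccccc1F`) gives 3600 nM on the same read-out. Compound 3 thus stands within the scatter of both other compounds, and the three numbers show no real order.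

Compound 4 (`O=C(Nc1ccccc1F)Nc1cc2ncncc2cc1OCc1cccc(Cl)c1`) keeps the 2-fluorophenyl on an amide-type nitrogen from compound 3 but has 3-chlorophenyl in place of 2-fluorophenyl on a saturated chain carbon bound to an oxygen on an aromatic ring. The same difference reads 2-fluorobenzyl to 3-chlorobenzyl.

Among the measured compounds shown here, no measured step covers this place. For the measured compounds named here, the one measured step is a 1.3-fold higher number from compound 1 to compound 2 (0.13 log units; within the scatter) and it concerns the group on an amide-type nitrogen, so it bears on this change only indirectly. The entering 3-chlorophenyl already stands in compound 1 at 3500 nM and in compound 2 at 4700 nM and neither value is set apart from compound 3 by more than the scatter. No step beyond the scatter is therefore expected in this assay and no direction can be given. The estimate amounts to a 1.1-fold higher number from compound 3 to compound 4 (0.02 log units; within the scatter) and is expected to stay within the scatter. For compound 4 the estimated value is 3800 nM with an expected range from 2000 nM to 7000 nM on this evidence.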

Compound 4, half-maximal inhibitory concentration: 4400 nM
For compound 4 the middle estimate is 1.2-fold (0.06 log units) below the measured one; low and high end bracket the measured number.
By their numbers in this assay, from the lowest: compounds 1, 3, 4 and 2 (each within the scatter of the next).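

In this assay the change from 2-fluorophenyl to 3-chlorophenyl on a saturated chain carbon bound to an oxygen on an aromatic ring now has a direct measurement, a 1.2-fold higher number from compound 3 to compound 4 (0.09 log units; within the scatter) and this first step at this position does not leave the scatter. With 3-chlorophenyl held at this position in compound 1, compound 2 and compound 4, the group on the amide-type nitrogen gives two more steps, a 1.1-fold lower number from compound 2 to compound 4 (0.03 log units; within the scatter) and a 1.3-fold higher number from compound 1 to compound 4 (0.10 log units; within the scatter) and both also stay within the scatter, so neither place yet separates the four compounds in this assay. No measurement at hand connects these numbers to any property of the groups.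

On these data alone, whether a step beyond the scatter appears with something other than a halogen-bearing phenyl on this carbon, such as a pyridine ring, an amine or a carboxylic acid, or with a longer chain in place of the benzyl group, remains open. The same question stands for the amide-type nitrogen, where only phenyl groups carrying fluorine, chlorine or trifluoromethyl appear so far.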